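The compounds below may be only part of what the source reports. "The series", "measured", "known", "first", "only" and "open" are said of these compounds alone.

Among the compounds with values here, compound 2 `COc1cccc(NC(=O)N[C@@H](C)c2ccccc2)c1` gives 99% in an ADME assay on the whole organism with Oryza sativa as the target, tested at 10 uM (a lower number here means a stronger effect, a higher number a weaker effect of the compound at the concentration tested), the higher of the two numbers recorded so far, though its gap to the only other compound lies within the scatter. That neighbour, compound 1 `C[C@H](NC(=O)Nc1cccc(C(F)(F)F)c1)c1ccccc1`, gives 92% in this assay; the step of a number 7 percentage points higher from compound 1 to compound 2 (within the scatter), methoxy in place of trifluoromethyl on an aromatic carbon, does not separate the two. Compound 3 `C[C@H](NC(=O)Nc1cccc(Br)c1)c1ccccc1` has not yet been measured. It differs from compound 2 in one place: bromo in place of methoxy on an aromatic carbon. Within the data shown here, the single measured step, a number 7 percentage points higher from compound 1 to compound 2 (within the scatter), is the only one that bears on it, as the one earlier exchange of a group on this aromatic carbon; it stayed within the scatter, so no move beyond the scatter is expected in this assay in either direction. Compound 3 is therefore estimated at 95% in this assay, with a range from 84% to 103%. The expected step is a number 4 percentage points lower from compound 2 to compound 3 (within the scatter).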

Compound 3, a percentage reported as activity, at one concentration (the size of the read-out at that concentration, not a potency): 99%
For compound 3 the middle estimate is 4 percentage points below the measured one, and the stated range covers the measured number.
By their numbers in this assay, from the lowest: compounds 1, 2 and 3 (each within the scatter of the next).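

With bromo as a third group on this aromatic carbon, meta to a large group, the picture in this assay extends beyond a single exchange: bromo in place of methoxy gives no change at the digits printed from compound 2 to compound 3 (within the scatter), and bromo in place of trifluoromethyl gives a number 7 percentage points higher from compound 1 to compound 3 (within the scatter). Methoxy, with its 2 heavy atoms and 1 hydrogen-bond acceptor, and bromo, with 1 heavy atom and 0 hydrogen-bond acceptors, are therefore not separated at this place, so among these three groups no exchange moves the number beyond the scatter. No measurement is available that explains why these groups are not separated.

On these data alone, whether an amine or a carboxylic acid on this aromatic carbon would give a step beyond the scatter stays open. So does whether a change elsewhere in the shared core would do so.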